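Spirocyclic sulfonyl ethers: amine cap exchange ahead of compound 4

This account rests on a few compounds, and the source may have more. Where it says the series, first, only, none or still open, it means among the compounds named here.

In a functional assay on cells for agonist activity at Glucose-dependent insulinotropic receptor (Homo sapiens), read by HTRF and cAMP accumulation, with a stated time of 30 min (on this read-out lower numbers stand for an effect already at smaller amounts and higher numbers for an effect only at larger amounts of compound), compound 1 `CC(C)(C)OC(=O)N1CCC2(CC1)CC2CCCOc1ccc(S(C)(=O)=O)cc1` gives 830 nM, compound 2 `CC(C)(C)OC(=O)N1CCC2(CCC(CCOc3ccc(S(C)(=O)=O)cc3)CC2)CC1` gives 55 nM, and compound 3 `CC(C)(C)OC(=O)N1CCC2(CC1)CC(CCCOc1ccc(S(C)(=O)=O)c(F)c1)C2` gives 9 nM. Compound 3 stands lowest of the three numbers; its gaps to compound 2 and to compound 1 are both beyond the scatter, so it is the most potent of the measured set. Compound 4 `CCc1cnc(N2CCC3(CC2)CC(CCCOc2ccc(S(C)(=O)=O)c(F)c2)C3)nc1` differs from compound 3 in one place: 5-ethylpyrimidin-2-yl in place of tert-butoxycarbonyl on an amine nitrogen in a ring. Going by the values given here, no measured pair shows this exchange, so nothing here fixes its size. A modest step toward a lower number, or none beyond the scatter, is expected, amounting to a 1.8-fold lower number from compound 3 to compound 4 (0.26 log units; within the scatter). For compound 4 in this assay the estimate is 5 nM, with a range from 1 nM to 30 nM.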

Compound 4, half-maximal effective concentration: 123 nM
For compound 4 the middle estimate is 25-fold (1.39 log units) below the measured one; measured number outside the range, above it.
By their numbers in this assay, from the lowest: compound 3; then compound 2; then compound 4; then compound 1.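

In this assay, going by these compounds alone, 5-ethylpyrimidin-2-yl in place of tert-butoxycarbonyl gives a 14-fold higher number from compound 3 to compound 4 (1.14 log units; beyond the scatter), the first single-place step. The amine nitrogen in a ring is therefore sensitive to the identity of its cap, even though both groups count the same hydrogen-bond donors and acceptors and neither carries a net charge. Nothing available accounts for the size of this step.

Open, going by these compounds, is whether a methyl or a trifluoromethyl in place of the ethyl would recover the lost ground. An isopropyl carbamate on the same nitrogen is also untested among the compounds shown here.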